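Series notes: aryl hydrazone variation on the shared core

A few compounds are considered here, and "the series" means these few. Any claim that something is new, unique, unknown or untested is made for them only; others in the source may bear on it.

Compound 3 `Cc1c(C(=O)N/N=C\c2ccccc2)oc2cccc(O)c12` gives 29200 nM in a functional assay on PC-3 cells (Homo sapiens) for inhibition (on this read-out lower numbers stand for stronger inhibition and higher numbers for weaker inhibition), the highest of the two numbers recorded, with compound 2 `Cc1c(C(=O)N/N=C\c2cccc(O)c2O)oc2cccc(O)c12` nearest at 12200 nM. Compound 1 `Cc1c(C(=O)N/N=C\c2ccc(C(F)(F)F)cc2)oc2cccc(O)c12` reached only a limit of the assay, >= 40000 nM. Compound 4 `Cc1c(C(=O)N/N=C\c2ccco2)oc2cccc(O)c12` has not been measured; it differs from compound 3 as follows: furan-2-yl in place of phenyl on a carbon with a double bond to nitrogen. For the measured compounds named here, two measured steps touch this position: a 2.4-fold higher number from compound 2 to compound 3 (0.38 log units; beyond the scatter), and an at least 1.3-fold lower number from compound 1 to compound 3 (0.13 log units; that floor lies within the scatter). Neither involves a five-membered ring, so the furan-2-yl change rests on thin ground; a step within the scatter is expected, tending toward a lower number given the direction seen for compound 2 at 12200 nM. Compound 4 is therefore estimated at 24000 nM, between 9000 nM and 60000 nM, meaning a 1.2-fold lower number from compound 3 to compound 4 (0.09 log units; within the scatter).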

Compound 4, half-maximal inhibitory concentration: >= 40000 nM
Compound 4 was reported as a limit (the forecaster's own chance of this, stated with the estimate: 30%); at least 1.6-fold (0.22 log units) between middle value and limit.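

Going by these compounds, compound 4 carries a limit of the assay, so furan-2-yl in place of phenyl can be read only as a floor, an at least 1.3-fold higher number from compound 3 to compound 4 (0.13 log units; that floor lies within the scatter), and the true size of this step stays unknown. Set against the 2,3-dihydroxyphenyl group, the same ring gives a step beyond the scatter, an at least 3.2-fold higher number from compound 2 to compound 4 (0.51 log units; beyond the scatter). Two of the aromatic groups at this position now end at the same limit: the limit of >= 40000 nM in this assay, at which 2 of the 4 values shown sit.

The compounds shown leave open whether an amine or a carboxylic acid on the phenyl ring would give a lower number than compound 2 at 12200 nM.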